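The compounds below may be only part of what the source reports. "The series", "measured", "known", "first", "only" and "open" are said of these compounds alone.

Measured in a functional assay on B16 cells (Mus musculus) for cytotoxicity, read by MTT assay, with a stated time of 48 h; on this read-out higher numbers stand for weaker inhibition and lower numbers for stronger inhibition:
- Compound 1 `C#Cc1ccc(NC(=O)c2cn(Cc3ccccc3)nn2)cc1`: > 100000 nM, a limit of the assay and not a number
- Compound 2 `C#Cc1ccc(NC(=O)c2cn(CCOC(C)=O)nn2)cc1`: 79000 nM
- Compound 3 `O=C(Nc1ccccc1)c1cn(Cc2ccccc2)nn1`: 93000 nM

Compound 3 at 93000 nM and compound 2 at 79000 nM lie within the scatter of each other. Compound 4 `CC(=O)OCCn1cc(C(=O)Nc2ccccc2)nn1` differs from compound 3 as follows: acetoxymethyl in place of phenyl on a saturated chain carbon bound to an aromatic nitrogen. This puts acetoxymethyl in place of phenyl, that is, benzyl to 2-acetoxyethyl. The same exchange appears in an at least 1.2-fold lower number from compound 1 to compound 2 (0.10 log units; that floor lies within the scatter), a step that starts from the limit of > 100000 nM in this assay, at which 1 of the 3 values shown sits. The removal of ethynyl, an at least 1.0-fold lower number from compound 1 to compound 3 (0.03 log units; that floor lies within the scatter), suggests that the two compound pairs need not differ much. In this assay, no change beyond the scatter is therefore expected. The expected step is a 1.2-fold lower number from compound 3 to compound 4 (0.07 log units; within the scatter). For compound 4 the estimate is 80000 nM, with an expected range of 40000 nM to 120000 nM.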

Compound 4, half-maximal inhibitory concentration: > 100000 nM
Compound 4: only a limit was reported; the forecaster's own chance of this, stated with the estimate: 25%; at least 1.2-fold (0.09 log units) between middle value and limit.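

In this assay compound 4 gives > 100000 nM, a limit of the assay and not a number. On this second core, the exchange of benzyl for 2-acetoxyethyl reads as an at least 1.0-fold higher number from compound 3 to compound 4 (0.03 log units; that floor lies within the scatter), and hydrogen in place of ethynyl reads as an at least 1.2-fold higher number from compound 2 to compound 4 (0.10 log units; that floor lies within the scatter), so neither change is shown to move the number beyond the scatter. Whether the exchange acts alike on both cores stays unsettled: the same change on two cores in this assay, an at least 1.2-fold lower number (0.10 log units; that floor lies within the scatter) from compound 1 to compound 2 and an at least 1.0-fold higher number (0.03 log units; that floor lies within the scatter) from compound 3 to compound 4; the limit leaves it open whether they differ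

The compounds shown leave open whether any group on this saturated chain carbon gives a clear step. An amine, a carboxylic acid or a longer chain in place of acetoxymethyl could answer that.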